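This account rests on a few compounds, and the source may have more. Where it says the series, first, only, none or still open, it means among the compounds named here.

The compounds measured so far in a functional assay on HeLa cells (Homo sapiens) for cytotoxicity, read by sulforhodamine B assay, with a stated time of 48 h; on this read-out lower numbers stand for stronger inhibition and higher numbers for weaker inhibition:

Compound 1 `CC(=O)OC[C@H]1O[C@@H](n2cc(Cn3cc(C(C)=O)c4ccccc43)nn2)[C@H](OC(C)=O)[C@@H](OC(C)=O)[C@@H]1OC(C)=O` gives > 200000 nM, which is a limit of the assay and not a number.
Compound 2 `CC(=O)OC[C@H]1O[C@@H](n2cc(CN3C(=O)/C(=C\c4ccc(N(C)C)cc4)c4ccccc43)nn2)[C@H](OC(C)=O)[C@@H](OC(C)=O)[C@@H]1OC(C)=O` gives 25000 nM.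
Compound 3 `CC(=O)OC[C@H]1O[C@@H](n2cc(CN3C(=O)/C(=C/c4ccc(N(C)C)cc4)c4ccccc43)nn2)[C@H](OC(C)=O)[C@@H](OC(C)=O)[C@@H]1OC(C)=O` gives 26300 nM.

Among the numbers shown, compound 3 stands highest, with compound 2 nearest. The step of a 1.1-fold higher number from compound 2 to compound 3 (0.02 log units; within the scatter) rests only on the fact that compounds 2 and 3 differ only in the configuration as drawn and lies within the scatter, so these two values show no real difference. Within the data shown here, compound 1 sits at the limit marked by the limit of > 200000 nM in this assay, at which 1 of the 3 values shown sits, while compound 2 gives a number; no single step is defined between them.

Compound 4 `CC(=O)OC[C@H]1O[C@@H](n2cc(CN3C(=O)/C(=C/c4ccco4)c4ccccc43)nn2)[C@H](OC(C)=O)[C@@H](OC(C)=O)[C@@H]1OC(C)=O` is compound 3 with one change: furan-2-yl in place of 4-(dimethylamino)phenyl on a double-bonded chain carbon bound to a double-bonded ring carbon. Among the measured compounds shown here, no measured step bears directly on this change, since the one step measured only swaps the drawn configuration of the double bond. The counted difference shows a smaller group entering, but nothing measured here tells how that should move the read-out. Compound 4 is therefore expected to give about 35000 nM, with a wide range from 12000 nM to 150000 nM. The expected step of a 1.3-fold higher number from compound 3 to compound 4 (0.12 log units; within the scatter) is small.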

Compound 4, half-maximal inhibitory concentration: 29900 nM
For compound 4 the middle estimate is 1.2-fold (0.07 log units) above the measured one; low and high end bracket the measured number.
By their numbers in this assay, from the lowest: compounds 2, 3 and 4 (each within the scatter of the next). At a limit, above all of these: compound 1.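

Among these compounds, compounds 2 and 3 differed only in the drawn configuration of the double bond, so this is the first change of the group itself on a double-bonded chain carbon bound to a double-bonded ring carbon. In this assay, putting furan-2-yl in place of 4-(dimethylamino)phenyl gives a 1.1-fold higher number from compound 3 to compound 4 (0.06 log units; within the scatter), so for this pair a smaller five-membered ring with oxygen and a larger six-membered carbon ring bearing the nitrogen group show no real difference. Nothing measured here explains why the read-out stays the same across this change.

Going by these compounds, it remains open whether a furan-2-yl compound with the double bond drawn the other way would also match compound 4. On these data alone, it is also open whether a carboxylic acid, a primary amine or a longer alkyl chain at this place would move the number beyond the scatter.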